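Substituent swap on the shared core and maximal response

The compounds below may be only part of what the source reports. "The series", "measured", "known", "first", "only" and "open" are said of these compounds alone.

Measured so far:
compound 1, `COc1c(C)ccc2c1CCC2c1ncc[nH]1`, 40%
compound 2, `CCCS(=O)(=O)Nc1cccc2c1CCC2c1ncc[nH]1`, 54%

In a functional assay on CHO cells for agonist activity at Alpha-1A adrenergic receptor (Homo sapiens), read by FLIPR and calcium flux (on this read-out higher numbers stand for larger maximal responses and lower numbers for smaller maximal responses), compound 2 gives 54%, the higher of the two numbers in hand. Within the data shown here, the only neighbour, compound 1, gives 40% in this assay, a gap that lies beyond the scatter; the two compounds differ in more than one place, so no single-point step is on record.

Compound 3, `Cn1nccc1-c1cccc2c1CCC2c1ncc[nH]1`, is not yet measured. It differs from compound 2 in one place: 1-methyl-1H-pyrazol-5-yl in place of (propylsulfonyl)amino on an aromatic carbon. The group that leaves carries one hydrogen-bond donor and no ring; the group that enters is a five-membered aromatic ring with no donor. Among the measured compounds shown here, no measured pair in this set shows the effect of such a swap, so the direction is open. With both measured numbers sitting in the middle of the range, a change in this assay that stays close to the scatter is the plain expectation.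

For compound 3 a maximal response of 46% is estimated in this assay, with a range from 20% to 72%. This estimate means a step of a number 8 percentage points lower from compound 2 to compound 3 (within the scatter), expected to be small and not clearly beyond the scatter.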

Compound 3, largest response reached (Emax), in percent of the reference or control that the assay uses: 58%
Compound 3: the middle estimate sits 12 percentage points below what was measured; the measured number falls inside the stated range.
By their numbers in this assay, from the lowest: compound 1; then compounds 2 and 3 (each within the scatter of the next).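

In this assay, among these compounds, the swap of (propylsulfonyl)amino for 1-methyl-1H-pyrazol-5-yl on this aromatic carbon gives the first single-point step (a number 4 percentage points higher from compound 2 to compound 3 (within the scatter)). On this pair, the position takes an open chain with a hydrogen-bond donor or a five-membered aromatic ring with no donor, and the maximal response stays within the scatter, so the donor of the leaving group is not needed to hold the response at this level. No measurement in hand accounts for this match between the two groups.

The compounds shown leave open how a primary amine, a carboxylic acid or an unsubstituted phenyl ring on this aromatic carbon would read, and whether any group there moves the maximal response beyond the scatter. Compound 1 differs from both of the others in more than one place, so the contribution of its methoxy and methyl groups cannot be read, and potency is not covered by this read-out of maximal response.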